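The compounds below may be only part of what the source reports. "The series", "measured", "known", "first", "only" and "open" are said of these compounds alone.

Compound 1, `COc1nc(-c2ccsc2)ccc1[C@@H](c1ccccc1)[C@@](O)(CCN(C)C)c1cccc2ccccc12`, was tested in a toxicity assay on Vero cells (Chlorocebus sabaeus) for cytotoxicity (a higher number here means that more compound is tolerated, a lower number that less compound is tolerated), and gave 24.4 ug/mL. Among the measured compounds shown here, that is the only true number in this small set. Compound 2, `COc1ncc(-c2ccccc2)cc1[C@@H](c1ccccc1)[C@@](O)(CCN(C)C)c1ccccc1`, is the other member; in this assay compound 2 gave > 50 ug/mL, which is a limit of the assay and not a measured number. One of the two values shown thus sits at the limit of > 50 ug/mL in this assay, at which 1 of the 2 values shown sits. For the measured compounds named here, with only one number available, no step between measured compounds can be drawn, and compound 1 cannot be ranked against compound 2 beyond what the limit itself states.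

Compound 3, `COc1nc(-c2ccc(Cl)cc2)ccc1[C@@H](c1ccccc1)[C@@](O)(CCN(C)C)c1cccc2ccccc12`, has not yet been measured. Compared with compound 1 it carries 4-chlorophenyl in place of thiophen-3-yl on an aromatic carbon. One five-membered aromatic ring with 1 hetero atom gives way to one six-membered aromatic ring of carbon only, and the rest of the molecule is unchanged. Going by the values given here, no step of this kind has been measured, so the expectation for compound 3 rests on compound 1 alone. In this assay a step of a 1.2-fold lower number from compound 1 to compound 3 (0.09 log units; within the scatter) is expected, no larger than the usual scatter. Compound 3 is therefore estimated at 20 ug/mL, in a range from 8 ug/mL to 50 ug/mL.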

Compound 3, half-maximal cytotoxic concentration: > 50 ug/mL
Compound 3: only a limit was reported (the forecaster's own chance of this, stated with the estimate: 12%); middle value at least 2.5-fold (0.39 log units) away from the limit.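

Replacing thiophen-3-yl with 4-chlorophenyl on the aromatic carbon next to the ring nitrogen gives an at least 2.0-fold higher number from compound 1 to compound 3 (0.31 log units; beyond the scatter) in this assay, so more of compound 3 is tolerated by the cells. Among the compounds shown here, this is the first direct sign that the group at this carbon affects the result, as compound 1 and compound 2 differ in more than one place and could not show it. The step gives only a minimum size, and the true gap may be larger, as the upper end of the test leaves the highest values without an exact number: the limit of > 50 ug/mL in this assay, at which 2 of the 3 values shown sit.

The change removes a five-membered ring containing sulfur and brings in a six-membered carbon ring carrying chlorine, so these compounds cannot show whether the ring, the chlorine or both matter. Also open, from the compounds shown here alone, is how a furan-3-yl group, a 4-fluorophenyl group or a ring bearing an amine at this carbon would behave in this assay, and whether the same change would have a similar effect with the other groups of the core altered.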